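The source may report more compounds than this note shows. Statements on the series, on what has been measured and on what is new or still open speak of the compounds shown alone.

Measured so far:
compound 1 `O=C(/C=C\Nc1ccc(C(F)(F)F)cc1)c1cn(-c2ccccc2)nc1-c1ccc(F)cc1`, > 50000 nM
compound 2 `COc1cc(-c2nn(-c3ccccc3)cc2C(=O)/C=C\Nc2ccc(F)cc2)cc(OC)c1OC`, 4780 nM

Going by the values given here, in a functional assay on U-87MG ATCC cells (Homo sapiens) for antiproliferative activity, read by MTT assay, with a stated time of 48 h (on this read-out higher numbers stand for weaker inhibition and lower numbers for stronger inhibition), compound 2 gives 4780 nM, the only numerical value in this set. Compound 1 is recorded only as a limit, > 50000 nM, which is the limit of > 50000 nM in this assay, at which 1 of the 2 values shown sits. Among the compounds with values here, compound 2 thus stands alone as the one compound with a measured number, and no single-change step between measured compounds exists here. Compound 3 `COc1cc(-c2nn(-c3ccccc3)cc2C(=O)/C=C\Nc2ccc(C(F)(F)F)cc2)cc(OC)c1OC` is the compound still to be measured; it differs from compound 2 by trifluoromethyl in place of fluoro on an aromatic carbon. Within the data shown here, no measured pair shows this same change, so its size cannot be read from these data. Compound 1 also carries a (4-(trifluoromethyl)phenyl)amino group and sits at the limit, but it differs from compound 2 in a second place too, so it is not a direct guide. The step from compound 2 to compound 3 is expected to be a modest loss, a 1.9-fold higher number from compound 2 to compound 3 (0.27 log units; within the scatter). Compound 3 is therefore estimated at 9000 nM, within a range from 2500 nM to 35000 nM.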

Compound 3, half-maximal inhibitory concentration: > 50000 nM
Compound 3 was reported as a limit; the forecaster's own chance of this, stated with the estimate: 15%; middle value at least 5.5-fold (0.74 log units) from the limit.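

Going by these compounds alone, with the 3,4,5-trimethoxyphenyl group held in place, the change from (4-fluorophenyl)amino to (4-(trifluoromethyl)phenyl)amino gives, in this assay, an at least 10-fold higher number from compound 2 to compound 3 (1.01 log units; beyond the scatter), the first single-change step that can be read in this set. At this aromatic carbon, para to a large group, the trifluoromethyl group therefore costs compound 3 the measurable activity that compound 2 shows with fluoro. Compound 3 is recorded only as a limit, and that limit is the one already held by compound 1: the limit of > 50000 nM in this assay, at which 2 of the 3 values shown sit.

Both values in the step from compound 1 to compound 3 are limits, and that step cannot be read, so the data do not show what the 3,4,5-trimethoxyphenyl group contributes when trifluoromethyl is present. Also open, as far as these compounds go, is how a chloro group, a nitrile or an amine at this same aromatic carbon would read in this assay.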